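Compound 3 in a cytotoxicity series held at the limit

The compounds below may be only part of what the source reports. "The series", "measured", "known", "first", "only" and "open" are said of these compounds alone.

- In an ADME assay on HepG2 cells (Homo sapiens) for cytotoxicity, read by luminescence, with a stated time of 72 h (a higher number here means that more compound is needed for the effect, a lower number that less compound is needed), compound 1 `CCOC(=O)c1c(-c2cccc(OC(F)(F)F)c2)[nH]c2cc(OC)c(F)cc2c1=O` gives > 21500 nM as a limit
- In this assay compound 2 `CCOC(=O)c1c(-c2cccc(-c3ccccc3Cl)c2)[nH]c2cc(OC)c(F)cc2c1=O` gives > 21500 nM as a limit
- Compound 3 `CCOC(=O)c1c(-c2cccc(-c3nc(C)c(C)s3)c2)[nH]c2cc(OC)c(F)cc2c1=O` has no measurement yet

Compound 2 has no number to its name, only a limit. Both measured compounds stand at the limit of > 21500 nM in this assay, at which 2 of the 2 values shown sit, and so neither can be placed against the other. The next change puts 4,5-dimethyl-1,3-thiazol-2-yl in place of 2-chlorophenyl on an aromatic carbon. For the measured compounds named here, the only measured step that bears on it is a step that the two limits leave unreadable from compound 1 to compound 2 and it has no size that can be read. No readable step is therefore expected in this assay and no direction can be given. This expectation rests on compound 2 with > 21500 nM as its limit and on the absence of any number in the series. The expected change is a step that the limit leaves unreadable from compound 2 to compound 3 and it is an estimate only. For compound 3 the estimated value is 25000 nM with an expected range from 12000 nM to 50000 nM and a report as a limit is the likeliest outcome.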

Compound 3, half-maximal effective concentration: > 21500 nM
Compound 3: only a limit was reported; the forecaster's own chance of this, stated with the estimate: 75%; the middle value does not contradict the limit.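

In this assay compound 3 gives > 21500 nM, a limit and not a number. The steps from compound 1 and compound 2 to compound 3 therefore cannot be read: the limit of > 21500 nM in this assay, at which 3 of the 3 values shown sit.

The compounds shown leave open at what concentration any of the three would reach the half-maximal effect, and whether the group on this aromatic carbon alters it.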